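Alkoxy chain exchange in a urea series, antagonist read-out

The source may report more compounds than this note shows. Statements on the series, on what has been measured and on what is new or still open speak of the compounds shown alone.

Measured so far:
compound 1 `Cc1cc(NNC(=O)Nc2cc(Cl)nc(Cl)c2)ncc1C#N`, 6000 nM
compound 2 `Cc1cc(CNC(=O)Nc2cc(Cl)nc(OCC(F)F)c2)nnc1-c1cn(C)nc1C(F)(F)F`, 7200 nM

In a functional assay on CHO cells for antagonist activity at sphingosine 1-phosphate receptor 2 (Homo sapiens), read by fluorescence and calcium flux, with a stated time of 3 min (a lower number here means a stronger inhibitor, a higher number a weaker inhibitor), compound 1 gives 6000 nM and compound 2 gives 7200 nM. Compound 2 carries the higher of the two numbers, but its gap to compound 1 lies within the scatter, so no order between the two can be read from these values. Within the data shown here, no two measured compounds differ in a single place, so no measured step is available in this assay.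

Compound 3 `COCCOc1cc(NC(=O)NCc2cc(C)c(-c3cn(C)nc3C(F)(F)F)nn2)cc(Cl)n1` has not yet been measured. It differs from compound 2 by methoxymethyl in place of difluoromethyl on a saturated chain carbon bound to an oxygen on an aromatic ring. Among the measured compounds shown here, nothing among the measured compounds bears on this exchange, and the two numbers in hand sit within the scatter of each other. The expectation is therefore a step of a 1.1-fold lower number from compound 2 to compound 3 (0.04 log units; within the scatter), none beyond the scatter in either direction. Compound 3 is expected to give 6500 nM in this assay, with a range from 2000 nM to 20000 nM.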

Compound 3, half-maximal inhibitory concentration: 412000 nM
Estimate against measurement, compound 3: 63-fold (1.80 log units) below; measured number outside the range, above it.
By their numbers in this assay, from the lowest: compounds 1 and 2 (each within the scatter of the next); then compound 3.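

In this assay, the saturated chain carbon bound to an oxygen on an aromatic ring proves sensitive to what it carries: methoxymethyl in place of difluoromethyl gives a 57-fold higher number from compound 2 to compound 3 (1.76 log units; beyond the scatter) with the rest of the structure unchanged. Compound 1 and compound 2 lie within the scatter of each other and differ in more than one place, so they gave no reading of this site, whereas this pair isolates a single exchange and shows that it alone moves the number well beyond the scatter, although the group leaving and the group entering each count 3 heavy atoms and differ by the carbon, fluorine and oxygen atoms and the one hydrogen-bond acceptor counted for methoxymethyl. No measurement in hand bears on the reason for a step of this size.

As far as these compounds go, whether the step follows the oxygen within the chain or the absence of the two fluorine atoms remains open, and an unfluorinated ethoxy chain, a 2-hydroxyethoxy chain or a longer 3-methoxypropoxy chain would be needed to separate these readings. From the compounds shown here alone, it is also open whether the same exchange carries the same weight on a different core.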